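A Butyl Group Rearranged to Tert-Butyl

The compounds below may be only part of what the source reports. "The series", "measured", "known", "first", "only" and "open" are said of these compounds alone.

In a physicochemical assay for lipophilicity (a lower number here means a more polar compound, a higher number a more lipophilic compound), compound 1 `O=C(O)CSC(CC(=O)c1ccccc1)C(=O)O` gives 0.71, compound 2 `CCc1ccc(C(=O)CC(SCC(=O)O)C(=O)O)cc1` gives 1.61, and compound 3 `CCCCc1ccc(C(=O)CC(SCC(=O)O)C(=O)O)cc1` gives 2.45, the highest of the three numbers. The measured series shows a number 0.90 log units higher from compound 1 to compound 2 (beyond the scatter) and a number 0.84 log units higher from compound 2 to compound 3 (beyond the scatter), both modest, while the whole span is large, at a number 1.74 log units higher from compound 1 to compound 3 (beyond the scatter). All three steps lie beyond the scatter, and each one adds carbon atoms to the shared core.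

Compound 4 `CC(C)(C)c1ccc(C(=O)CC(SCC(=O)O)C(=O)O)cc1` differs from compound 3 by tert-butyl in place of butyl on an aromatic carbon, which is tert-butyl in place of butyl on an aromatic carbon. Within the data shown here, the same atoms are joined differently, so no carbon is gained, and none of the measured steps gauges this change directly. Even the smallest of them, a number 0.84 log units higher from compound 2 to compound 3 (beyond the scatter), came with added carbon, so a step of that size is not expected in this assay. The expected result is no step beyond the scatter, with an estimated a number 0.10 log units lower from compound 3 to compound 4 (within the scatter). Compound 4 is expected at 2.35, within an estimated range of 2.05 to 2.6.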

Compound 4, partition coefficient: 2.41
For compound 4 the middle estimate is 0.06 log units below the measured one; low and high end bracket the measured number.
By their numbers in this assay, from the lowest: compound 1; then compound 2; then compounds 4 and 3 (each within the scatter of the next).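

Among these compounds, at this place, on an aromatic carbon para to a large group, the earlier compounds showed only steps that added carbon, whereas tert-butyl in place of butyl keeps the same atoms and gives a number 0.04 log units lower from compound 3 to compound 4 (within the scatter) in this assay and so shows that, for this pair, rejoining those atoms moved the number by no more than the scatter. Tert-butyl also stands clear of the smaller groups, with a number 0.80 log units higher from compound 2 to compound 4 (beyond the scatter) and a number 1.70 log units higher from compound 1 to compound 4 (beyond the scatter) in the same read-out. Nothing given here bears on why butyl and tert-butyl read alike.

The compounds shown leave open whether a longer chain such as hexyl or a ring such as cyclohexyl at this place would continue the rise. They also leave open whether an amine or a hydroxyl there would lower the number.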